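The source may hold more compounds than are shown below. What is called first, only, known or untested is meant among the compounds shown, and "the series" means these compounds.

Measured so far: compound 1 `COc1ccccc1CN(C)Cc1ccc(/C=C2\Oc3cc(OC)c(OC)cc3C2=O)cc1O` gives 8.4% in an assay on cells for inhibition of Amine oxidase [flavin-containing] B (Homo sapiens), read by fluorescence, with a stated time of 30 min, tested at 10 uM (on this read-out lower numbers stand for less inhibition and higher numbers for more inhibition at the one concentration tested (going by the name of the read-out)), and compound 2 `COc1cc2c(cc1OC)C(=O)/C(=C/c1ccc(CN(C)Cc3ccccc3)c(O)c1)O2` gives 17.8%.

For the measured compounds named here, compound 2 and compound 1 sit within the scatter of each other, the only step between them being a number 9.4 percentage points higher from compound 1 to compound 2 (within the scatter). Compound 3 `CCN(Cc1ccccc1)Cc1ccc(/C=C2\Oc3cc(OC)c(OC)cc3C2=O)cc1O` differs from compound 2 by methyl in place of hydrogen on a saturated chain carbon bound to an amine nitrogen. Going by the values given here, no measured step touches a change of this kind; the single known step, a number 9.4 percentage points higher from compound 1 to compound 2 (within the scatter), concerns a different place and is itself within the scatter. Compound 3 is therefore expected to give about 18%, somewhere between 5% and 32%. The step of a number 0.2 percentage points higher from compound 2 to compound 3 (within the scatter) is expected to stay within the scatter.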

Compound 3, a percentage reported as inhibition, at one concentration (the size of the read-out at that concentration, not a potency): 23.9%
The estimate for compound 3 lay 5.9 percentage points below the measured number; low and high end bracket the measured number.
By their numbers in this assay, from the lowest: compounds 1, 2 and 3 (each within the scatter of the next, the first and the last beyond it).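

Changing benzyl(methyl)amino to benzyl(ethyl)amino gives a number 6.1 percentage points higher from compound 2 to compound 3 (within the scatter), so this change alone cannot be told apart from repeat-measurement noise. For the compounds shown here, replacing (2-methoxybenzyl)(methyl)amino with benzyl(ethyl)amino, which alters both the benzyl group and the other chain on the amine, gives a number 15.5 percentage points higher from compound 1 to compound 3 (beyond the scatter), a modest difference that is the first here to clear the scatter. Nothing available explains either step.

Going by these compounds, it remains open whether a longer chain such as propyl, or a pyrrolidine ring in place of the open-chain amine, would move the number clearly. Also open, on these data alone, is which of the two alterations in the larger step matters more.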